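The source may hold more compounds than are shown below. What is called first, only, known or untested is meant among the compounds shown, and "the series" means these compounds.

Measured in a functional assay on L1210 cells (Mus musculus) for antiproliferative activity; on this read-out lower numbers stand for stronger inhibition and higher numbers for weaker inhibition:
- compound 1 `COC1=C(OCc2ccc([N+](=O)[O-])cc2)/C(=C\Cn2cnc3c(Cl)ncnc32)OC1=O`: 5810 nM
- compound 2 `COC1=C(OCc2ccc([N+](=O)[O-])cc2)C(=O)O/C1=C/Cn1cnc2c(Cl)ncnc21`: 6030 nM

Compound 2, at 6030 nM, stands level with compound 1, at 5810 nM. Going by the values given here, the two values lie within the scatter of each other, so the series so far offers a single level of activity and no spread.

The next compound to be tested is compound 3 `O=C1O/C(=C/Cn2cnc3c(Cl)ncnc32)C(OCc2ccc([N+](=O)[O-])cc2)=C1OCc1ccc([N+](=O)[O-])cc1`. Its difference from compound 2 is 4-nitrophenyl in place of hydrogen on a saturated chain carbon bound to an oxygen on an unsaturated carbon, which also reads as methoxy to (4-nitrobenzyl)oxy.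

Among the compounds with values here, no measured pair shows this change, so the data give no direct size for it. The expectation in this assay therefore starts from compound 2 at 6030 nM: a small move toward stronger inhibition is slightly favoured, probably not beyond the scatter, and the uncertainty runs both ways. The expected change is a 1.5-fold lower number from compound 2 to compound 3 (0.18 log units; within the scatter). The estimated value for compound 3 is 4000 nM, with an expected range from 1200 nM to 15000 nM.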

Compound 3, half-maximal inhibitory concentration: > 120000 nM
Compound 3 was reported as a limit (the forecaster's own chance of this, stated with the estimate: 10%); middle value at least 30-fold (1.47 log units) from the limit.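

Compounds 1 and 2 stood level and gave no step, so the series had shown no change that moved the read-out in this assay. On a saturated chain carbon bound to an oxygen on an unsaturated carbon, 4-nitrophenyl in place of hydrogen, which reads as methoxy to (4-nitrobenzyl)oxy, is not tolerated in this assay, with an at least 19-fold higher number from compound 2 to compound 3 (1.29 log units; beyond the scatter) and an at least 20-fold higher number from compound 1 to compound 3 (1.31 log units; beyond the scatter). The reading for compound 3 is a limit and not a number, so each step gives only a lower bound and the full size of the loss stays unknown: the limit of > 120000 nM in this assay, at which 1 of the 3 values shown sits.

The compounds shown hold only methoxy and (4-nitrobenzyl)oxy at this place, which leaves open whether the loss goes with the benzyl part or with the nitro group on it; a plain benzyloxy, an ethoxy or a free hydroxyl there would help to separate these readings. Also open, from the compounds shown here alone, is whether a longer chain ending in a carboxylic acid or an amine at the same place would keep the level of compound 1 and compound 2.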